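A few compounds are considered here, and "the series" means these few. Any claim that something is new, unique, unknown or untested is made for them only; others in the source may bear on it.

In a functional assay on PC-3 cells (Homo sapiens) for cytotoxicity, read by sulforhodamine B assay (on this read-out lower numbers stand for stronger inhibition of growth and higher numbers for weaker inhibition of growth), compound 1 `COc1cccc(OC)c1OCCNCCOc1ccccc1OCc1ccc(Cl)cc1` gives 14500 nM.
In this assay compound 2 `COc1cccc(OC)c1OCCNCCOc1ccccc1OCc1ccccc1C` gives 33900 nM.
In this assay compound 3 `COc1cccc(OC)c1OCCNCCOc1ccccc1OCc1ccc(C)cc1` gives 27500 nM.

All three measured compounds share one core and differ only in the group carried on a saturated chain carbon bound to an oxygen on an aromatic ring. On the numbers shown, compound 3 stands second highest of the three. Its nearest neighbour is compound 2, with a 1.2-fold lower number from compound 2 to compound 3 (0.09 log units; within the scatter), and its furthest is compound 1, with a 1.9-fold higher number from compound 1 to compound 3 (0.28 log units; within the scatter), so compound 3 cannot be set apart from either by this assay. For the measured compounds named here, the one step that reaches beyond the scatter is a 2.3-fold higher number from compound 1 to compound 2 (0.37 log units; beyond the scatter), which is still modest.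

Compound 4 `COc1cccc(OC)c1OCCNCCOc1ccccc1OCc1cccc([N+](=O)[O-])c1` is the next compound in this series; compared with compound 3 the change is 3-nitrophenyl in place of 4-methylphenyl on a saturated chain carbon bound to an oxygen on an aromatic ring. All three measured steps concern the same position and bear on this change, but none of them introduces a nitro group, so they only show that swapping substituents at this position has so far moved this assay by modest amounts at most. The step from compound 3 to compound 4 is therefore expected to be small, in either direction, as a 1.3-fold lower number from compound 3 to compound 4 (0.10 log units; within the scatter). Compound 4 is estimated at 22000 nM, within a range from 8000 nM to 55000 nM.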

Compound 4, concentration for total growth inhibition: 38900 nM
Beside the measured number, compound 4's estimate is 1.8-fold (0.25 log units) below it; the range from low to high includes it.
By their numbers in this assay, from the lowest: compounds 1, 3, 2 and 4 (each within the scatter of the next, the first and the last beyond it).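

In this assay, 3-nitrophenyl on a saturated chain carbon bound to an oxygen on an aromatic ring cannot be told apart from either methylphenyl group, with a 1.4-fold higher number from compound 3 to compound 4 (0.15 log units; within the scatter) and with a 1.1-fold higher number from compound 2 to compound 4 (0.06 log units; within the scatter) as the two readings. Against 4-chlorophenyl it does separate, with a 2.7-fold higher number from compound 1 to compound 4 (0.43 log units; beyond the scatter) as the largest step yet seen at this place, though that step is still modest. The hydrogen-bond acceptors counted on 3-nitrophenyl, absent from 4-methylphenyl, come with no step beyond the scatter, and no outside evidence bears on this result.

Going by these compounds, how 4-nitrophenyl, or a phenyl ring carrying an amine or a carboxylic acid, would read in this assay remains open. So does whether any group at this place can produce more than a modest step.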